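A few compounds are considered here, and "the series" means these few. Any claim that something is new, unique, unknown or untested is made for them only; others in the source may bear on it.

Of the compounds shown here, three of a shared core have been measured for how strongly they slow the growth of breast cancer cells. In a functional assay on MCF7 cells (Homo sapiens) for antiproliferative activity, read by MTT assay, with a stated time of 72 h (on this read-out lower numbers stand for stronger inhibition and higher numbers for weaker inhibition), compound 1 `CCN1CCN(c2cc(C)c3cc(NC(=O)c4cccc(Cl)c4)ccc3n2)CC1` gives 3820 nM, which places it second highest of the three numbers. Compound 2 `CCNc1cc(C)c2cc(NC(=O)c3ccc(Cl)c(Cl)c3)ccc2n1` gives 48600 nM, the highest and therefore the weakest of the three, while compound 3 `CCN(CC)CCNc1cc(C)c2cc(NC(=O)c3ccc(Cl)c(Cl)c3)ccc2n1` gives 1420 nM, the lowest and strongest. Among the compounds with values here, the only single-point comparison among the measured compounds is a 34-fold lower number from compound 2 to compound 3 (1.53 log units; beyond the scatter), a change on the chain attached to the core, not at the carbonyl carbon.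

Compound 4 `CCN1CCN(c2cc(C)c3cc(NC(=O)c4ccccc4OC)ccc3n2)CC1` differs from compound 1 by 2-methoxyphenyl in place of 3-chlorophenyl on a carbonyl carbon. Within the data shown here, no measured step touches this part of the molecule, so nothing here tells how the assay responds to a change at the carbonyl carbon; the expectation for compound 4 therefore rests on compound 1 alone and is uncertain in direction. Compound 4 is expected to give 6000 nM, somewhere between 1500 nM and 25000 nM, which means an expected step of a 1.6-fold higher number from compound 1 to compound 4 (0.20 log units; within the scatter).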

Compound 4, half-maximal inhibitory concentration: 13200 nM
Compound 4: middle estimate off by 2.2-fold (0.34 log units), on the low side; the measured number falls inside the stated range.
By their numbers in this assay, from the lowest: compound 3; then compound 1; then compound 4; then compound 2.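

Within the data shown here, this is the first measured change at the carbonyl carbon, and it shows that this part of the molecule matters: with everything else in compound 1 kept, 2-methoxyphenyl in place of 3-chlorophenyl gives a 3.5-fold higher number from compound 1 to compound 4 (0.54 log units; beyond the scatter) in this assay. The step lies beyond the scatter, so the position is not indifferent to the ring it carries, and of these two rings 3-chlorophenyl gives the stronger inhibition. Nothing measured here gives a reason for the loss.

The two rings differ both in which group they carry and in where it sits, so this single step cannot separate those two changes. Going by these compounds, how a plain phenyl ring or a pyridine ring on the same carbonyl carbon would compare with 3-chlorophenyl remains open.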